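Testing One Amine Swap on a Second Core

A few compounds are considered here, and "the series" means these few. Any claim that something is new, unique, unknown or untested is made for them only; others in the source may bear on it.

Of the compounds shown here, three built on closely related cores have been measured for how strongly they stop the growth of human cervical tumour cells. Compound 1 `Cc1ccc2c(c1)[n+]([O-])c(NCCN1CCCCC1)n[n+]2[O-]` is the reference point; in a functional assay on SiHa cells (Homo sapiens) for cytotoxicity, with a stated time of 4 h (a higher number here means a weaker inhibitor, a lower number a stronger inhibitor), compound 1 gives 2200 nM. Compound 2 `CCCN(CCC)CCNc1n[n+]([O-])c2ccc(C)cc2[n+]1[O-]` differs from compound 1 in a single place: dipropylamino in place of piperidin-1-yl on a saturated chain carbon, two bonds along the chain from a nitrogen on an aromatic ring. In this assay compound 2 gives 600 nM, and the step is a 3.7-fold lower number from compound 1 to compound 2 (0.56 log units; beyond the scatter).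

Compound 3 `CC(C)c1ccc2c(c1)[n+]([O-])c(NCCN1CCCCC1)n[n+]2[O-]` keeps the amine of compound 1 but sits on a different core; the two cores differ as follows: isopropyl in place of methyl on an aromatic carbon. In this assay compound 3 gives 1100 nM, and the step is a 2.0-fold lower number from compound 1 to compound 3 (0.30 log units; within the scatter), so compounds 1 and 3 cannot be told apart on this evidence.

Compound 4 `CCCN(CCC)CCNc1n[n+]([O-])c2ccc(C(C)C)cc2[n+]1[O-]` has not yet been measured in this assay. It differs from compound 3 in one place: dipropylamino in place of piperidin-1-yl on a saturated chain carbon, two bonds along the chain from a nitrogen on an aromatic ring. This is the same change that turned compound 1 into compound 2, made at the same place on the chain, only now on the core of compound 3. The step from compound 3 to compound 4 is expected to be a 3.3-fold lower number from compound 3 to compound 4 (0.52 log units; beyond the scatter), because the same change once gave a 3.7-fold lower number from compound 1 to compound 2 (0.56 log units; beyond the scatter) and the two cores sit within the scatter of each other. Going by the values given here, with only one earlier instance to rest on, the spread is kept wide. Compound 4 is therefore estimated at 330 nM in this assay, with a likely range from 140 nM to 800 nM.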

Compound 4, half-maximal inhibitory concentration: 900 nM
Estimate against measurement, compound 4: 2.7-fold (0.44 log units) below; the whole stated range lies below it.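

Made on the core of compound 3, the swap of piperidin-1-yl for dipropylamino gives a 1.2-fold lower number from compound 3 to compound 4 (0.09 log units; within the scatter) in this assay, so the clear step seen on the core of compound 1 does not reappear at the same size, and the two steps differ: the same change on two cores in this assay, a 3.7-fold lower number (0.56 log units; beyond the scatter) from compound 1 to compound 2 and a 1.2-fold lower number (0.09 log units; within the scatter) from compound 3 to compound 4, 3.0-fold (0.48 log units) apart, beyond the scatter of two such steps

The same four compounds can be read the other way, with isopropyl in place of methyl on an aromatic carbon: among the dipropylamino compounds this gives a 1.5-fold higher number from compound 2 to compound 4 (0.18 log units; within the scatter), and that step and its piperidin-1-yl counterpart, each small on its own, also differ: the same change on two cores in this assay, a 2.0-fold lower number (0.30 log units; within the scatter) from compound 1 to compound 3 and a 1.5-fold higher number (0.18 log units; within the scatter) from compound 2 to compound 4, 3.0-fold (0.48 log units) apart, beyond the scatter of two such steps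

Together these comparisons show that, for these two cores, the effect of the amine swap depends on the group on the aromatic carbon, so the step from one core should not simply be added onto the other; they do not show why this happens, nor how the swap would behave on any third core.

From the compounds shown here alone, it remains open whether an ethyl group or a plain hydrogen on that aromatic carbon would give a step closer to the one on the core of compound 1 or to the one on the core of compound 3. Going by these compounds, it also remains open whether a different amine, such as morpholine or diethylamino, or a longer chain would show the same dependence on the core.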